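Bromo to methoxy on two pyrazoline series

This account rests on a few compounds, and the source may have more. Where it says the series, first, only, none or still open, it means among the compounds named here.

Measured compounds:
compound 1 `Cn1cc(C2CC(c3ccccc3)=NN2C(=O)c2cccnc2)c2cc(Br)ccc21` 1600 nM
compound 2 `COc1ccc2c(c1)c(C1CC(c3ccccc3)=NN1C(=O)c1cccnc1)cn2C` > 10000 nM
compound 3 `COc1ccc2c(c1)c(C1CC(c3ccc(Br)cc3)=NN1C(=O)c1ccc(OC)nc1)cn2C` > 10000 nM

In a functional assay on A549 cells (Homo sapiens) for inhibition, read by MTT assay, with a stated time of 48 h (on this read-out higher numbers stand for weaker inhibition of growth and lower numbers for stronger inhibition of growth), compound 1 gives 1600 nM. Compound 2 reaches only the limit of the assay, > 10000 nM. The step of an at least 6.2-fold higher number from compound 1 to compound 2 (0.79 log units; beyond the scatter) is the change (methoxy in place of bromo on an aromatic carbon). Compound 3 likewise sits at a limit and not at a number, > 10000 nM. How the core of compound 3 differs from that of compound 1 is not broken down here.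

Compound 4 `COc1ccc(C2=NN(C(=O)c3ccc(OC)nc3)C(c3cn(C)c4ccc(OC)cc34)C2)cc1` is not yet measured. It differs from compound 3 by methoxy in place of bromo on an aromatic carbon. This is the same kind of change as that from compound 1 to compound 2, but not the same: there the bromo sat on a ring that is part of a fused system, here it sits on a six-membered aromatic ring of carbon only, para to a large group. Because compound 3 already sits at the limit of > 10000 nM in this assay, at which 2 of the 3 values shown sit, the step that the limit leaves unreadable from compound 3 to compound 4 is expected to be small or to leave compound 4 at the limit. Compound 4 is expected to give 15000 nM, somewhere between 5000 nM and 50000 nM.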

Compound 4, concentration for 50% growth inhibition: 450 nM
Estimate against measurement, compound 4: 33-fold (1.52 log units) above; measured number outside the range, below it.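

In this assay, exchanging 4-bromophenyl for 4-methoxyphenyl gives an at least 22-fold lower number from compound 3 to compound 4 (1.34 log units; beyond the scatter), so compound 4 is clearly stronger than compound 3 at inhibiting growth. Methoxy in place of bromo therefore does not carry over between these cores with one direction or one size: the same change on two cores in this assay, an at least 6.2-fold higher number (0.79 log units; beyond the scatter) from compound 1 to compound 2 and an at least 22-fold lower number (1.34 log units; beyond the scatter) from compound 3 to compound 4, at least 130-fold (2.14 log units) apart, beyond the scatter of two such steps. This does not show what sets the direction, as the change sits at a different place in each pair and the two pairs also differ elsewhere, and the full size of each step remains unread, as each rests on a limit.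

The compounds shown leave open whether an amine, a carboxylic acid or a longer chain such as ethoxy on the six-membered aromatic ring of carbon only would act as methoxy does. They also leave open whether 4-methoxyphenyl would lower the number on the core of compound 1, where bromo is kept.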